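A few compounds are considered here, and "the series" means these few. Any claim that something is new, unique, unknown or untested is made for them only; others in the source may bear on it.

Measured compounds in the series:

- compound 1 `O=C1c2sc(C#Cc3ccccc3)nc2CN1C1CC1`: 23 nM
- compound 2 `Fc1cccc(C#Cc2nc3c(s2)CN(C2CCC2)CC3)c1`: 200 nM
- compound 3 `O=C(C1CC1)N1CCc2nc(C#Cc3ccccc3)sc2C1`: 290 nM

All three were run in an assay on HEK293 cells for negative allosteric modulation of metabotropic glutamate receptor 5 (Homo sapiens), read by FLIPR, with a stated time of 1 h; a lower number here means a stronger inhibitor, a higher number a weaker inhibitor. Among the three numbers, compound 3 gives the highest, at 290 nM. Its nearest neighbour is compound 2, whose number lies within the scatter of that of compound 3, so no order between the two can be read. The gap to compound 1 is beyond the scatter, and compound 1 stands as the strongest inhibitor of the three.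

The next compound, compound 4 `O=C(C1CCCCO1)N1CCc2nc(C#Cc3ccccc3)sc2C1`, differs from compound 3 in one place: oxan-2-yl in place of cyclopropyl on a carbonyl carbon. Cut one bond further out, the change reads cyclopropylcarbonyl to (oxan-2-yl)carbonyl, on the amide-type nitrogen in a ring. No measured pair in the series shows a change of this kind, so the size of the step cannot be taken from the data shown. The expectation is a modest step toward a higher number in this assay, roughly at the edge of the scatter, from 290 nM for compound 3. For compound 4 the estimated step is a 1.6-fold higher number from compound 3 to compound 4 (0.19 log units; within the scatter). Compound 4 is thus expected at 450 nM, within a range of 150 nM to 1400 nM.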

Compound 4, half-maximal inhibitory concentration: > 10000 nM
Compound 4: a limit, no number; the forecaster's own chance of this, stated with the estimate: 5%; middle value at least 22-fold (1.34 log units) away from the limit.
By their numbers in this assay, from the lowest: compound 1; then compounds 2 and 3 (each within the scatter of the next). At a limit, above all of these: compound 4.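

On the carbonyl carbon, oxan-2-yl in place of cyclopropyl gives an at least 34-fold higher number from compound 3 to compound 4 (1.53 log units; beyond the scatter), the first step readable at this position. Compound 4 stands at a limit of this assay and not at a number: the limit of > 10000 nM in this assay, at which 1 of the 4 values shown sits. This position is therefore not indifferent to the group it carries, since this one change, which brings a six-membered ring with a ring oxygen, is enough to take compound 4 out of the measurable range.

The compounds shown do not separate the ring size from the ring oxygen, and a cyclohexyl group on the same carbonyl carbon would tell the two apart. Also open, on these data alone, is how an amine or a simple methyl group at this place would read in this assay.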